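Chain extension between triazole and aryl ether oxygen

The compounds below may be only part of what the source reports. "The series", "measured", "known", "first", "only" and "open" are said of these compounds alone.

Measured in an assay on CHO cells for displacement of a labelled ligand from D(4) dopamine receptor (Homo sapiens); a higher number here means a weaker inhibitor, a lower number a stronger inhibitor:
compound 1 `COc1cc(CN2CCN(c3ccccc3OC)CC2)ccc1OCCCCc1cn(CCCCCCCCCCn2cc(CCCCOc3ccc(CN4CCN(c5ccccc5OC)CC4)cc3OC)nn2)nn1`: 11 nM
compound 2 `CCCCn1cc(COc2ccc(CN3CCN(c4ccccc4OC)CC3)cc2OC)nn1`: 3.3 nM
compound 3 `CCOCCn1cc(COc2ccc(CN3CCN(c4ccccc4OC)CC3)cc2OC)nn1`: 8.4 nM

Compound 3 stands second highest of the three numbers; compound 1 sits within the scatter of it, while compound 2 lies lower, beyond the scatter. Compound 4 `CCOCCn1cc(CCCOc2ccc(CN3CCN(c4ccccc4OC)CC3)cc2OC)nn1` carries 2-(1-(2-ethoxyethyl)-1H-1,2,3-triazol-4-yl)ethyl in place of 1-(2-ethoxyethyl)-1H-1,2,3-triazol-4-yl on a saturated chain carbon bound to an oxygen on an aromatic ring. Among the measured compounds shown here, no measured step changes this linker; the only step in hand, a 2.5-fold higher number from compound 2 to compound 3 (0.41 log units; beyond the scatter), concerns the chain on the triazole nitrogen and is modest. Chain lengthening next to the aryl ether oxygen is therefore untested here, and the expectation for compound 4 rests on compound 3 alone. Compound 4 is expected to change little, a 1.2-fold higher number from compound 3 to compound 4 (0.08 log units; within the scatter), with a wide range to reflect the absence of a bearing step. Estimated: compound 4 at 10 nM, between 3 nM and 35 nM.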

Compound 4, inhibition constant: 6.4 nM
Compound 4: the middle estimate sits 1.6-fold (0.19 log units) above what was measured; the measured number falls inside the stated range.
By their numbers in this assay, from the lowest: compounds 2, 4, 3 and 1 (each within the scatter of the next, the first and the last beyond it).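

In this assay, the 2-(1-(2-ethoxyethyl)-1H-1,2,3-triazol-4-yl)ethyl group gives a 1.3-fold lower number from compound 3 to compound 4 (0.12 log units; within the scatter), so the number does not respond measurably to this extension on a saturated chain carbon bound to an oxygen on an aromatic ring. Against the 1-butyl-1H-1,2,3-triazol-4-yl group, the same group gives a 1.9-fold higher number from compound 2 to compound 4 (0.29 log units; within the scatter), so this pair stays within the scatter. No supporting data explain this tolerance.

Still open, on these data alone, is whether a longer chain or an amine in the same place would also leave the number unchanged.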